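Extending the methoxy of compound 3 to an isopropoxy group

The source may hold more compounds than are shown below. What is called first, only, known or untested is meant among the compounds shown, and "the series" means these compounds.

Measured compounds so far:
compound 1, `COc1cccc(OC)c1OCCNCCOc1ccccc1OCc1ccc(Cl)cc1`, 8.06;
compound 2, `COc1cccc(COc2ccccc2OCCNCCOc2c(OC)cccc2OC)c1`, 8.31;
compound 3, `COc1ccc(COc2ccccc2OCCNCCOc2c(OC)cccc2OC)cc1`, 9.51.

All three numbers come from a functional assay on spleen for antagonist activity at Alpha-1B adrenergic receptor (Rattus norvegicus); on this read-out higher numbers stand for higher potency (the scale is a negative logarithm) and lower numbers for lower potency. Compound 3 stands highest of the three, and its lead is beyond the scatter in both directions: a number 1.45 log units higher from compound 1 to compound 3 (beyond the scatter) and a number 1.20 log units higher from compound 2 to compound 3 (beyond the scatter). The step between compound 1 and compound 2 is small: a number 0.25 log units higher from compound 1 to compound 2 (within the scatter).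

Compound 4, `COc1cccc(OC)c1OCCNCCOc1ccccc1OCc1ccc(OC(C)C)cc1`, has not been measured yet. It differs from compound 3 in one place: isopropyl in place of methyl on an oxygen on an aromatic ring. The two large steps show that the group on this end of the molecule matters a great deal, but neither of them compares a methoxy with a larger alkoxy group, so the direction of this change is not settled by the numbers in hand. Without a direct precedent, compound 4 is expected to stay close to compound 3, with a modest fall in this assay allowed for: a number 0.41 log units lower from compound 3 to compound 4 (beyond the scatter). The estimate for compound 4 is 9.1, within a range from 8.3 to 9.8.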

Compound 4, negative logarithm of the antagonist equilibrium constant: 8.62
Beside the measured number, compound 4's estimate is 0.48 log units above it; measured number inside the range.
By their numbers in this assay, from the lowest: compounds 1 and 2 (each within the scatter of the next); then compound 4; then compound 3.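

On this assay the change from methoxy to isopropoxy is a real loss (a number 0.89 log units lower from compound 3 to compound 4 (beyond the scatter)), so the alkyl group on this oxygen is not a free choice, and the high number of compound 3 depends on more than having an oxygen at this place. Part of the advantage survives: the 4-isopropoxyphenyl group still stands above the 3-methoxyphenyl group (a number 0.31 log units higher from compound 2 to compound 4 (beyond the scatter)), and isopropoxy still stands above chloro (a number 0.56 log units higher from compound 1 to compound 4 (beyond the scatter)). Nothing measured here explains why methoxy outperforms isopropoxy in this series.

From the compounds shown here alone, with only these two alkoxy groups to compare, it remains open whether an ethoxy group would stay close to methoxy or fall as far as isopropoxy. Also unknown is how a hydroxy group or a longer butoxy chain on this ring would fare.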